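Working notes on a shared-core amide series, compound 3

The source may report more compounds than this note shows. Statements on the series, on what has been measured and on what is new or still open speak of the compounds shown alone.

Measured compounds:
compound 1 `O=C(CSc1nc(Nc2ccccc2)c2ccccc2n1)Nc1ccccc1Cl`: 14600 nM
compound 2 `O=C(CSc1nc(Nc2ccccc2)c2ccccc2n1)Nc1ccc(F)cc1`: 9560 nM

In a functional assay on PC-3 cells (Homo sapiens) for inhibition, read by MTT assay, with a stated time of 72 h (on this read-out lower numbers stand for stronger inhibition and higher numbers for weaker inhibition), compound 1 gives 14600 nM and compound 2 gives 9560 nM. The only measured step, a 1.5-fold lower number from compound 1 to compound 2 (0.18 log units; within the scatter), lies within the scatter, so compound 2 and compound 1 stand together on the numbers shown. Compound 3 `O=C(CSc1nc(Nc2ccccc2)c2ccccc2n1)Nc1ccc(C(F)(F)F)cc1` is not yet measured. Its change from compound 2 is trifluoromethyl in place of fluoro on an aromatic carbon, with the shared core and the amide untouched. Among the measured compounds shown here, no measured step involves a trifluoromethyl; the single measured step changed the aryl on the amide nitrogen and stayed within the scatter. A step of similar small size is therefore expected in this assay for compound 3, in no clear direction. Compound 3 is estimated at 8000 nM, range 3000 nM to 25000 nM. The expected step is a 1.2-fold lower number from compound 2 to compound 3 (0.08 log units; within the scatter).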

Compound 3, half-maximal inhibitory concentration: 10400 nM
Compound 3: the middle estimate sits 1.3-fold (0.11 log units) below what was measured; low and high end bracket the measured number.
By their numbers in this assay, from the lowest: compounds 2, 3 and 1 (each within the scatter of the next).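

In this assay, trifluoromethyl in place of fluoro on this aromatic carbon, para to a large group, gives a 1.1-fold higher number from compound 2 to compound 3 (0.04 log units; within the scatter) and so adds heavy atoms at this position with no step beyond the scatter. The comparison with the 2-chlorophenyl amide gives a 1.4-fold lower number from compound 1 to compound 3 (0.15 log units; within the scatter) and also stays within the scatter, so all three aryl amides stand together on these numbers. No supporting data bear on why this change leaves the number within the scatter.

Open, as far as these compounds go, is whether an amine or a carboxylic acid on this aromatic carbon would give a step beyond the scatter. Also open, from the compounds shown here alone, is how a longer chain in place of the aryl on the amide nitrogen would read.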